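The source may hold more compounds than are shown below. What is called first, only, known or untested is meant among the compounds shown, and "the series" means these compounds.

Compound 1 `O=C(Nc1ccccc1)Nc1cccc(Nc2nccc(Nc3ccc4cn[nH]c4c3)n2)c1` and compound 2 `O=C(Nc1ccccc1)Nc1ccc(Nc2nccc(Nc3ccc4cn[nH]c4c3)n2)cc1` are built from the same atoms joined differently, and the difference between their two cores is not broken down here. In a functional assay on HepG2 cells (Homo sapiens) for inhibition, read by fluorescence and resazurin assay, with a stated time of 72 h (on this read-out higher numbers stand for weaker inhibition and lower numbers for stronger inhibition), compound 1 gives 8200 nM. Compound 2 gives 11000 nM, and these two numbers lie within the scatter of each other, so neither compound can be called the stronger inhibitor.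

Compound 3 `O=C(Nc1ccc(Nc2nccc(Nc3ccc4cn[nH]c4c3)n2)cc1)Nc1cccc(F)c1` is compound 2 carrying one further atom: fluoro in place of hydrogen on an aromatic carbon. In this assay compound 3 gives 6600 nM, which means a 1.7-fold lower number from compound 2 to compound 3 (0.22 log units; within the scatter). Compound 4 `O=C(Nc1ccc(F)cc1)Nc1cccc(Nc2nccc(Nc3ccc4cn[nH]c4c3)n2)c1` has not yet been measured. It stands to compound 1 as compound 3 stands to compound 2, bearing the change (fluoro in place of hydrogen on an aromatic carbon). The two places are not identical: in compound 3 the fluoro sits meta to a large group, in compound 4 it sits para to a large group. So the move from compound 1 to compound 4 is the same kind of change as the one from compound 2 to compound 3, not the same change.

Within the data shown here, with only one earlier example of a fluoro entering in this region of the molecule, and that example giving a step within the scatter, the expectation for compound 4 is a step of similar size, a 1.3-fold lower number from compound 1 to compound 4 (0.10 log units; within the scatter), resting on the step from compound 2 to compound 3 of a 1.7-fold lower number from compound 2 to compound 3 (0.22 log units; within the scatter). On that basis compound 4 is expected to give about 6500 nM, most likely between 3000 nM and 15000 nM.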

Compound 4, half-maximal inhibitory concentration: 12000 nM
Beside the measured number, compound 4's estimate is 1.8-fold (0.27 log units) below it; measured number inside the range.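

In this assay, putting a fluoro on the phenyl ring of compound 1 gives a 1.5-fold higher number from compound 1 to compound 4 (0.17 log units; within the scatter), which means the change has no readable effect on this core, just as it had none on the earlier one. Set side by side, the results on the two cores cannot be told apart: the same change on two cores in this assay, a 1.7-fold lower number (0.22 log units; within the scatter) from compound 2 to compound 3 and a 1.5-fold higher number (0.17 log units; within the scatter) from compound 1 to compound 4, 2.4-fold (0.39 log units) apart, within the scatter of two such steps This shows no sign that the core alters what a fluoro does here, but it does not show that the change carries over from one core to the other, as neither step can be told from no change at all and the fluoro does not sit in the same place in compound 3 and compound 4.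

The compounds shown carry only hydrogen or fluoro on this outer phenyl ring, and it remains open whether a different group there, such as a trifluoromethyl, a methoxy or a carboxylic acid, would give a step beyond the scatter on either core. Going by these compounds, it also remains open whether a fluoro set in the same place on both cores would give matching steps.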